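This account rests on a few compounds, and the source may have more. Where it says the series, first, only, none or still open, it means among the compounds named here.

Series notes. Compound 1 `CCN1CCCC1CNC(=O)c1cc(NS(=O)(=O)NC)ccc1OC` is the reference. In a functional assay on the whole organism for inhibition, with Canis familiaris (Canis lupus familiaris) as the target (a lower number here means that less compound is needed, a higher number that more compound is needed for the effect), compound 1 gives only a limit, > 1 mg/kg. Compound 2 `CCN1CCCC1CNC(=O)c1cc(NS(=O)(=O)NC)c(C)cc1OC` differs from compound 1 by methyl in place of hydrogen on an aromatic carbon. In this assay compound 2 also gives only a limit, > 1 mg/kg. The step that the two limits leave unreadable from compound 1 to compound 2 therefore cannot be sized, as the limit of > 1 mg/kg in this assay, at which 2 of the 3 values shown sit, shows. Compound 3 `CCN1CCCC1CNC(=O)c1cc(NS(N)(=O)=O)ccc1OC` differs from compound 1 by hydrogen in place of methyl on a sulfonamide nitrogen. In this assay compound 3 gives 10 mg/kg. The step that the limit leaves unreadable from compound 1 to compound 3 likewise remains without a size. Compound 4 `CCN1CCCC1CNC(=O)c1cc(NS(N)(=O)=O)c(C)cc1OC` is not yet measured; it differs from compound 3 by methyl in place of hydrogen on an aromatic carbon, the same kind of change as from compound 1 to compound 2, though here the place is ortho to a sulfamoylamino group rather than to a (methylsulfamoyl)amino group. For compound 4 the expected step is no change at the digits printed from compound 3 to compound 4 (within the scatter). This rests on compound 3 with 10 mg/kg and on the unread step that the two limits leave unreadable from compound 1 to compound 2, which gives no direction. The estimate for compound 4 in this assay is 10 mg/kg, between 3 mg/kg and 30 mg/kg.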

Compound 4, dose for half-maximal effect: > 1 mg/kg
Compound 4 gave a limit, no number (the forecaster's own chance of this, stated with the estimate: 30%); the middle value does not contradict the limit.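

Compound 4 gives only a limit, > 1 mg/kg, so its steps from compound 3 and compound 2 cannot be read. The compounds shown leave open whether methyl in place of hydrogen on an aromatic carbon changes the dose in this assay.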